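The source may hold more compounds than are shown below. What is called first, only, known or untested is meant among the compounds shown, and "the series" means these compounds.

Values in a functional assay on 1-87 cells (Homo sapiens) for cytotoxicity; a lower number here means a stronger inhibitor, a higher number a weaker inhibitor:

- compound 1 `COc1ccc(/C=C\c2cc(OC)c(OC)c(OC)c2)cc1B(O)O`: 13 nM
- compound 2 `COc1cc(/C=C\c2cccc(B(O)O)c2)cc(OC)c1OC`: 2100 nM
- compound 3 `COc1cc(/C=C\c2ccc(OC)c(B(O)O)c2)cc(OC)c1`: 28 nM

Compound 1 has the lowest number of the three, and its steps to both others lie beyond the scatter. Compound 4 `COc1ccc(/C=C\c2cc(OC)c(OC)c(OC)c2)cc1C(=O)O` is the next to consider, with one change from compound 1: a group of 3 heavy atoms (1 carbon, 2 oxygen; no ring) in place of a group of 3 heavy atoms (1 boron, 2 oxygen; no ring), on an aromatic carbon. Carboxy thus takes the place of the boron-containing group, ortho to a methoxy group.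

Among the measured compounds shown here, no measured step alters that group, so the evidence is indirect. Both measured steps put hydrogen in place of methoxy. On the ring that carries the boron-containing group, this gave a 160-fold higher number from compound 1 to compound 2 (2.21 log units; beyond the scatter). On the other ring, it gave a 2.2-fold higher number from compound 1 to compound 3 (0.33 log units; beyond the scatter). The first step shows that a single change on the ring concerned can cost much in this assay, and that ring is where compound 4 differs.

A large step towards a higher number is therefore expected, estimated as a 120-fold higher number from compound 1 to compound 4 (2.06 log units; beyond the scatter). For compound 4 the expected value is 1500 nM, with an estimated range from 150 nM to 15000 nM.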

Compound 4, half-maximal inhibitory concentration: 110000 nM
Beside the measured number, compound 4's estimate is 73-fold (1.87 log units) below it, outside the stated range (above it).
By their numbers in this assay, from the lowest: compound 1; then compound 3; then compound 2; then compound 4.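

In this assay, among the compounds shown here, putting carboxy in place of the boron-containing group gives an 8500-fold higher number from compound 1 to compound 4 (3.93 log units; beyond the scatter), the first direct reading of a change to this group itself. The two groups match in heavy-atom count and neither carries a net charge, yet this step exceeds the one on the same ring, a 160-fold higher number from compound 1 to compound 2 (2.21 log units; beyond the scatter), so this position is highly sensitive to the identity of the group, not only to its size as counted in heavy atoms. Nothing measured on these compounds bears on the origin of this loss.

For the compounds shown here, with only two groups read at this position, it remains open whether an amine or a carboxamide there would fall nearer compound 1 or nearer compound 4. Also open, on these data alone, is whether the step would keep its size with a group other than methoxy ortho to it.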